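The compounds below may be only part of what the source reports. "The series", "measured", "known", "first", "only" and "open" are said of these compounds alone.

Measured so far:
- compound 1, `Cc1cccc(/C=N/Nc2ncc3c(n2)n(C2CCCC2)c(=O)c(=O)n3C)c1`: 53600 nM
- compound 2, `Cn1c(=O)c(=O)n(C2CCCC2)c2nc(N/N=C/c3ccc(S(C)(=O)=O)cc3)ncc21`: 26600 nM

In a functional assay on PC-3 cells (Homo sapiens) for antiproliferative activity, read by MTT assay (on this read-out lower numbers stand for stronger inhibition and higher numbers for weaker inhibition), compound 2 gives 26600 nM, the lowest of the two numbers, with compound 1 nearest and within the scatter. Within the data shown here, the one measured step, a 2.0-fold lower number from compound 1 to compound 2 (0.30 log units; within the scatter), came from exchanging a 3-methylphenyl for a 4-(methylsulfonyl)phenyl on the carbon double-bonded to nitrogen, and stayed within the scatter.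

Compound 3, `COc1cccc(/C=N/Nc2ncc3c(n2)n(C2CCCC2)c(=O)c(=O)n3C)c1`, is the next compound. Its change from compound 2 is 3-methoxyphenyl in place of 4-(methylsulfonyl)phenyl on a carbon with a double bond to nitrogen. The incoming 3-methoxyphenyl resembles the 3-methylphenyl of compound 1 more than the group it replaces, so the measured step bears on it only loosely, and that step was small. No step beyond the scatter is therefore expected in this assay, though a somewhat higher number, back toward compound 1, seems more likely than a lower one. For compound 3 the estimate is 40000 nM, within 15000 nM to 110000 nM, which means an expected step of a 1.5-fold higher number from compound 2 to compound 3 (0.18 log units; within the scatter).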

Compound 3, half-maximal inhibitory concentration: 20700 nM
Beside the measured number, compound 3's estimate is 1.9-fold (0.29 log units) above it; the measured number falls inside the stated range.
By their numbers in this assay, from the lowest: compounds 3, 2 and 1 (each within the scatter of the next, the first and the last beyond it).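

In this assay, the step of a 2.6-fold lower number from compound 1 to compound 3 (0.41 log units; beyond the scatter) is the only one so far beyond the scatter, though still modest, and it comes from methoxy in place of methyl on an aromatic carbon. This shows that a small exchange on the aromatic ring, with the rest of the molecule unchanged, can register in this assay. The step of a 1.3-fold lower number from compound 2 to compound 3 (0.11 log units; within the scatter) stays within the scatter, so 3-methoxyphenyl and 4-(methylsulfonyl)phenyl cannot be told apart here, and no measurement is available to explain either step.

From the compounds shown here alone, whether an amine, a carboxylic acid or a chlorine on the aromatic ring at this place would give a larger step remains open. Going by these compounds, all three compounds share the same core, so changes elsewhere on it also remain open.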